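From Propyl to 4-Cyanophenyl on the Shared Core

A few compounds are considered here, and "the series" means these few. Any claim that something is new, unique, unknown or untested is made for them only; others in the source may bear on it.

Within the data shown here, in a physicochemical assay for lipophilicity, measured as octanol-water partition (on this read-out higher numbers stand for higher lipophilicity and lower numbers for lower lipophilicity), compound 2 `CCCC1C(C(=O)OCc2ccccn2)=C(C)NC2=C1C(=O)CCC2` gives 2.6, the highest of the three numbers measured so far and beyond the scatter from both others. Compound 1 `CC1=C(C(=O)OCc2cccnc2)C(c2ccco2)C2=C(CCCC2=O)N1` gives 1.03, and compound 3 `CC1=C(C(=O)OCc2cccnc2)C(c2cccc(O)c2)C2=C(CCCC2=O)N1` gives 1.21. Compound 4 `CC1=C(C(=O)OCc2ccccn2)C(c2ccc(C#N)cc2)C2=C(CCCC2=O)N1` has not yet been measured. It replaces the propyl of compound 2 with 4-cyanophenyl on a saturated ring carbon: 4-cyanophenyl in place of propyl on a saturated ring carbon.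

Among the measured compounds shown here, only one measured step bears on this change, and only indirectly. It exchanges one ring group for another at that carbon, 3-hydroxyphenyl in place of furan-2-yl, and amounts to a number 0.18 log units higher from compound 1 to compound 3 (within the scatter). For the measured compounds named here, no measured step replaces propyl with a ring, and compounds 1 and 3 also differ from compound 2 in the ester. Their values therefore offer only a loose guide, with compound 1 at 1.03 and compound 3 at 1.21. A moderate downward step is expected, estimated as a number 0.80 log units lower from compound 2 to compound 4 (beyond the scatter). For compound 4, the estimated value in this assay is 1.8, with an expected range of 1.1 to 2.6.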

Compound 4, partition coefficient: 1.73
Estimate against measurement, compound 4: 0.07 log units above, and the stated range covers the measured number.
By their numbers in this assay, from the lowest: compounds 1 and 3 (each within the scatter of the next); then compound 4; then compound 2.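

Among these compounds, the exchange of propyl for 4-cyanophenyl on this saturated ring carbon, with the ester left unchanged, is the first step here that goes from a chain to a ring, and in this assay it reads as a number 0.87 log units lower from compound 2 to compound 4 (beyond the scatter) on this read-out. Among the compounds shown here, the earlier step at this carbon joined two ring groups and stayed within the scatter, so this is the first sign that a change at this position can move the number beyond it. Nothing measured here explains the size of the step, and the result cannot separate the loss of propyl from the entry of the aromatic ring or the nitrile.

Where an unsubstituted phenyl or a longer chain such as pentyl would fall at this carbon remains open. So does whether the same exchange would give a similar step with the ester of compounds 1 and 3.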